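This account rests on a few compounds, and the source may have more. Where it says the series, first, only, none or still open, it means among the compounds named here.

Of the compounds shown here, three of one shared core have been measured so far. In a functional assay on A549 cells (Homo sapiens) for cytotoxicity, read by MTT assay, with a stated time of 48 h (a higher number here means a weaker inhibitor, a lower number a stronger inhibitor), compound 1 `Cc1ccc(Cn2cc(COc3ccc4c(=O)ccoc4c3)nn2)cc1` gives 50700 nM. Compound 2 `O=c1ccoc2cc(OCc3cn(Cc4ccc(Cl)cc4Cl)nn3)ccc12` gives 5260 nM in this assay, the lowest of the two numbers recorded. Compound 3 `C#CCOc1ccc2c(=O)ccoc2c1` reaches only a limit of this assay, > 100000 nM, and no number. For the measured compounds named here, the one step measured between neighbours, a 9.6-fold lower number from compound 1 to compound 2 (0.98 log units; beyond the scatter), came with a 2,4-dichlorophenyl in place of a 4-methylphenyl on a saturated chain carbon bound to an aromatic nitrogen.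

Compound 4 `COc1ccc(Cn2cc(COc3ccc4c(=O)ccoc4c3)nn2)cc1` is not yet measured. Relative to compound 2 its change is 4-methoxyphenyl in place of 2,4-dichlorophenyl on a saturated chain carbon bound to an aromatic nitrogen. Going by the values given here, the step of a 9.6-fold lower number from compound 1 to compound 2 (0.98 log units; beyond the scatter) bears on it: a 4-methylphenyl at this position gave the higher number, so a 4-methoxyphenyl, a comparably small group at the same position, is expected to move back toward compound 1, though the single measured step is a thin basis. In this assay compound 4 is therefore estimated at 40000 nM, within 12000 nM to 100000 nM, an expected step of a 7.6-fold higher number from compound 2 to compound 4 (0.88 log units; beyond the scatter).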

Compound 4, half-maximal inhibitory concentration: 16500 nM
Compound 4: the middle estimate sits 2.4-fold (0.38 log units) above what was measured, within the range that was stated.
By their numbers in this assay, from the lowest: compound 2; then compound 4; then compound 1. At a limit, above all of these: compound 3.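

With a third substituted phenyl on a saturated chain carbon bound to an aromatic nitrogen, this assay now gives an order of three groups rather than a single step, and 4-methoxyphenyl falls in the middle. The 2,4-dichlorophenyl of compound 2 keeps the lowest number, with a 3.1-fold higher number from compound 2 to compound 4 (0.50 log units; beyond the scatter), while the swap of methoxy for methyl on an aromatic carbon gives a 3.1-fold lower number from compound 1 to compound 4 (0.49 log units; beyond the scatter). So the number responds not only to the change to 2,4-dichlorophenyl but also to this smaller swap, which lies beyond the scatter.

The compounds shown leave open where a plain phenyl, a 4-chlorophenyl or a phenyl carrying an amine or a carboxylic acid would fall in this order. Nothing shown gives a reason for these differences.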